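Working notes: the step from compound 2 to compound 3

The source may hold more compounds than are shown below. What is called first, only, known or untested is meant among the compounds shown, and "the series" means these compounds.

In an ADME assay on Raji cells (Homo sapiens) for cytotoxicity, with a stated time of 72 h (a higher number here means that more compound is needed for the effect, a lower number that less compound is needed), compound 1 (`Cc1ccc(NC(=O)Nc2cc(C)nc3ccccc23)cc1`) gives > 25000 nM as a limit and not a number. In this assay compound 2 (`Cc1cc(NC(=O)Nc2ccc(O)cc2)c2ccccc2n1`) gives > 25000 nM as a limit too. Compound 2 therefore stands at the limit of > 25000 nM in this assay, at which 2 of the 2 values shown sit, and has no readable number.

Compound 3 (`Cc1cc(NC(=O)Nc2cccnc2)c2ccccc2n1`) carries pyridin-3-yl in place of 4-hydroxyphenyl on an amide-type nitrogen. For the measured compounds named here, the only measured step is a step that the two limits leave unreadable from compound 1 to compound 2 and it gives no size to carry over. Going by the values given here, no measured step tests this exchange, so no shift beyond the usual scatter is expected in this assay and no direction can be argued. The estimated step is a number no higher from compound 2 to compound 3 (the limit leaves the size open) and is an expectation only. The estimate for compound 3 is 25000 nM with an expected range from 12000 nM to 50000 nM and a limit is the likeliest report.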

Compound 3, half-maximal effective concentration: > 25000 nM
Compound 3 ended at the assay's limit; the forecaster's own chance of this, stated with the estimate: 85%; the middle value lies on the limit itself.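

Compound 2 and compound 3, like compound 1, give only a limit and not a number, so no step among these compounds can be read: the limit of > 25000 nM in this assay, at which 3 of the 3 values shown sit.

The compounds shown leave open whether any group on the amide-type nitrogen gives a readable half-maximal effective concentration in this assay.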